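This account rests on a few compounds, and the source may have more. Where it says the series, first, only, none or still open, it means among the compounds named here.

The series shares one core, shown in compound 1 `CC(C)[C@H](NC(=O)COc1cccc2ccccc12)C(=O)N[C@@H](CC(=O)O)C(=O)CSc1ncc[nH]1`, and varies only the group on the saturated chain carbon bound to the carbonyl carbon. In a functional assay on Jurkat cells (Homo sapiens) for inhibition (on this read-out lower numbers stand for stronger inhibition and higher numbers for weaker inhibition), compound 1 gives > 200000 nM, which is a limit of the assay and not a number. Compound 2 `CC(C)[C@H](NC(=O)COc1cccc2ccccc12)C(=O)N[C@@H](CC(=O)O)C(=O)CSc1nccn1C`, with methyl in place of hydrogen on an aromatic nitrogen, gives > 200000 nM in this assay, again a limit. Compound 3 `CC(C)[C@H](NC(=O)COc1cccc2ccccc12)C(=O)N[C@@H](CC(=O)O)C(=O)CSc1nc2ccccc2o1` in this assay gives > 200000 nM, also a limit. All three values share (the limit of > 200000 nM in this assay, at which 3 of the 3 values shown sit). The steps a step that the two limits leave unreadable from compound 1 to compound 2, a step that the two limits leave unreadable from compound 1 to compound 3 and a step that the two limits leave unreadable from compound 2 to compound 3 therefore cannot be read in size or direction.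

Compound 4 `CC(C)[C@H](NC(=O)COc1cccc2ccccc12)C(=O)N[C@@H](CC(=O)O)C(=O)COc1nc2ccccc2[nH]1` differs from compound 1 by (1H-benzimidazol-2-yl)oxy in place of (1H-imidazol-2-yl)sulfanyl on a saturated chain carbon bound to a carbonyl carbon. Among the measured compounds shown here, no measured step bears on this change in a readable way: the exchange of the ring on the sulfur in the steps ending at compound 3 stayed unreadable, and no measured pair replaces the sulfur with an oxygen. With every measured compound at the limit, the expected outcome for compound 4 is that it too is reported at the limit, the step that the limit leaves unreadable from compound 1 to compound 4 being all that can be said. Compound 4 is estimated at 300000 nM, with a range from 60000 nM to 1500000 nM.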

Compound 4, half-maximal inhibitory concentration: > 200000 nM
Compound 4 ended at the assay's limit (the forecaster's own chance of this, stated with the estimate: 75%); the middle value lies beyond the limit too.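

In this assay compound 4 gives > 200000 nM, which is a limit and not a number, so its steps from compound 1, compound 2 and compound 3 cannot be read in size or direction. All four compounds share one limit: the limit of > 200000 nM in this assay, at which 4 of the 4 values shown sit. The compounds shown leave open how they rank against one another and whether any group at this place gives a readable inhibition in this assay.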